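The compounds below may be only part of what the source reports. "The series", "measured", "known", "first", "only" and "open" are said of these compounds alone.

Working notes on a small series sharing one core. Compound 1 `COc1ccc(NC(=O)NC2CC(C)(C)Oc3ccc(Br)cc32)cc1` and compound 2 `Cc1cccc(NC(=O)NC2CC(C)(C)Oc3ccc(F)cc32)c1` have been run in a functional assay (aorta) with Rattus norvegicus as the target; a lower number here means that less compound is needed, a higher number that more compound is needed for the effect. For compound 1 the outcome is a limit rather than a number, > 10000 nM. For compound 2 the outcome is likewise a limit, > 30000 nM. Among the measured compounds shown here, both measured values are therefore limits, one sitting at the limit of > 10000 nM in this assay, at which 1 of the 2 values shown sits, and one at the limit of > 30000 nM in this assay, at which 1 of the 2 values shown sits, so no step between measured compounds can be drawn, and compound 2 stands only at the limit of the limit of > 30000 nM in this assay, at which 1 of the 2 values shown sits, with no numerical potency to anchor it.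

Compound 3 `Cc1cccc(NC(=O)NC2CC(C)(C)Oc3ccc(Br)cc32)c1` is the next compound to be measured in this assay. It differs from compound 2 by bromo in place of fluoro on an aromatic carbon. Compound 1 already carries bromo at that same place and returned only a limit, so the two measured limits give no ground to expect an outcome that enters the measured range. No step beyond the scatter in either direction is expected, and the expected step of a number no higher from compound 2 to compound 3 (the limit leaves the size open) is an estimate resting on the two measured limits. For compound 3 the expected value in this assay is 30000 nM, with a range from 10000 nM to 100000 nM, and most likely reported again only as a limit.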

Compound 3, half-maximal effective concentration: > 10000 nM
Compound 3 gave a limit, no number; the forecaster's own chance of this, stated with the estimate: 80%; the middle value is on the limit's open side.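

Among the compounds shown here, compound 3 gives only a limit in this assay, as do compound 1 and compound 2, so no step linking compound 3 to either of them can be read. The compounds shown leave open whether any member of this series gives a measured number in this assay, and whether either exchange changes the effect there.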